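This account rests on a few compounds, and the source may have more. Where it says the series, first, only, none or still open, it means among the compounds named here.

Measured so far in an assay on isolated protein for inhibition of coagulation factor X (Oryctolagus cuniculus), tested at 1 uM; on this read-out lower numbers stand for less inhibition and higher numbers for more inhibition at the one concentration tested (going by the name of the read-out):
compound 1 `O=C1[C@@H](NS(=O)(=O)c2ccc(-c3ccon3)s2)CCN1Cc1cc2c[nH]ccc-2n1`: 17%
compound 2 `O=C1[C@@H](NS(=O)(=O)c2ccc(-c3ccon3)s2)CCN1Cc1cc2[nH]cccc-2n1`: 31%
compound 3 `O=C1[C@@H](NS(=O)(=O)c2ccc(-c3ccon3)s2)CCN1Cc1cc2cc[nH]cc-2n1`: 49%

Compound 1 stands lowest of the three numbers in this assay. The nearest measured step is a number 14 percentage points higher from compound 1 to compound 2 (beyond the scatter); the furthest is a number 32 percentage points higher from compound 1 to compound 3 (beyond the scatter); the remaining pair shows a number 18 percentage points higher from compound 2 to compound 3 (beyond the scatter). All three steps exchange the group on the saturated chain carbon bound to the amide-type nitrogen in the ring.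

Compound 4 `O=C1[C@@H](NS(=O)(=O)c2cc3nc(Cl)ccc3s2)CCN1Cc1cc2c[nH]ccc-2n1` differs from compound 1 elsewhere: a group of 10 heavy atoms (7 carbon, 1 nitrogen, 1 sulfur, 1 chlorine; one five-membered aromatic ring with 1 hetero atom, one six-membered aromatic ring with 1 hetero atom) in place of a group of 10 heavy atoms (7 carbon, 1 nitrogen, 1 oxygen, 1 sulfur; one five-membered aromatic ring with 1 hetero atom, one five-membered aromatic ring with 2 hetero atoms), on a sulfonyl sulfur. Going by the values given here, none of the measured steps touches the sulfonyl sulfur, so none of them bears on this change; no direction can be read from the series. The expectation therefore rests on compound 1 alone, which gives 17%, with a wide range around it.

Compound 4 is expected to give 20% in this assay, between 5% and 50%. The step this estimate means is a number 3 percentage points higher from compound 1 to compound 4 (within the scatter), not expected to exceed the scatter.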

Compound 4, a percentage reported as inhibition, at one concentration (the size of the read-out at that concentration, not a potency): 58%
For compound 4 the middle estimate is 38 percentage points below the measured one; measured number above the stated range.
By their numbers in this assay, from the lowest: compound 1; then compound 2; then compounds 3 and 4 (each within the scatter of the next).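

The earlier steps shown here all exchanged the group on the saturated chain carbon; this result shows that the read-out in this assay also responds to the group on the sulfonyl sulfur. Replacing 5-(1,2-oxazol-3-yl)thiophen-2-yl with the chlorine-bearing group gives a number 41 percentage points higher from compound 1 to compound 4 (beyond the scatter). No measurement here accounts for this step.

From the compounds shown here alone, whether the same exchange carries over to the groups of compound 2 and compound 3 remains open. Also open, going by these compounds, is what the chlorine contributes beyond the ring change, which a methoxy or nitrile in its place could separate.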